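This account rests on a few compounds, and the source may have more. Where it says the series, first, only, none or still open, it means among the compounds named here.

In a functional assay on K562 cells (Homo sapiens) for antiproliferative activity, read by MTT assay, with a stated time of 48 h (on this read-out lower numbers stand for stronger inhibition and higher numbers for weaker inhibition), compound 1 (`Oc1ccc2c(c1)CCc1ccc(O)c(c1)Oc1ccc(cc1)CCc1cccc(O)c1O2`) gives 14100 nM as its value, compound 2 (`Oc1ccc2c(c1)CCc1ccc(O)c(c1)Oc1ccc(cc1O)CCc1cccc(O)c1O2`) gives 25300 nM and compound 3 (`Oc1ccc2cc1Oc1ccc(cc1)CCc1ccc(O)c(c1)Oc1cccc(c1)CC2`) gives 7020 nM in the same test. Compound 3 cannot be told apart from compound 1 within the scatter, and only compound 2 stands clearly above it, beyond the scatter.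

Compound 4 (`Oc1ccc2cc1Oc1cccc(c1)CCc1ccc(O)c(c1)Oc1ccc(cc1O)CC2`), still unmeasured, carries a single change relative to compound 3 (hydroxy in place of hydrogen on an aromatic carbon), namely hydroxy in place of hydrogen on an aromatic carbon. Among the compounds with values here, the only measured step of this kind, also hydroxy in place of hydrogen on an aromatic carbon, is a 1.8-fold higher number from compound 1 to compound 2 (0.25 log units; within the scatter) and it stays within the scatter. One small step, taken in a different compound, is thin support, so its size is carried over and its upward direction is held only loosely. In this assay what is expected is therefore a 1.6-fold higher number from compound 3 to compound 4 (0.20 log units; within the scatter) and no shift beyond the scatter. For compound 4 the estimated value is 11000 nM with an expected range from 5000 nM to 25000 nM in this measurement.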

Compound 4, half-maximal inhibitory concentration: 10900 nM
Beside the measured number, compound 4's estimate is 1.0-fold (0.00 log units) above it; measured number inside the range.
By their numbers in this assay, from the lowest: compounds 3, 4, 1 and 2 (each within the scatter of the next, the first and the last beyond it).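

With a 1.6-fold higher number from compound 3 to compound 4 (0.19 log units; within the scatter) in this assay, hydroxy in place of hydrogen on an aromatic carbon has now been read on a second core, so the earlier single step no longer stands alone. The two steps point the same way and match closely in size: the same change on two cores in this assay, a 1.8-fold higher number (0.25 log units; within the scatter) from compound 1 to compound 2 and a 1.6-fold higher number (0.19 log units; within the scatter) from compound 3 to compound 4, 1.2-fold (0.06 log units) apart, within the scatter of two such steps. On the core of compound 3, at this place on a six-membered aromatic ring of carbon only, ortho to a fused ring and meta to a fused ring, the added hydroxy therefore leaves the number within the scatter, and the same holds for the step on the other core, so neither step alone establishes a weakening.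

Whether methoxy, an amine or a carboxylic acid at this place would move the number beyond the scatter remains open, as hydroxy is the only group shown entering here. Also open, as far as these compounds go, is whether the agreement between these two small steps would hold on further cores, and the numbers themselves give no account of what lies behind the change.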